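The source may report more compounds than this note shows. Statements on the series, on what has been measured and on what is new or still open speak of the compounds shown alone.

In a functional assay on CCRF-CEM cells (Homo sapiens) for cytotoxicity, read by MTT assay, with a stated time of 24 h, tested at 10 uM (on this read-out lower numbers stand for a stronger effect and higher numbers for a weaker effect at the one concentration tested), compound 2 `N#CCCCCn1cnc2c(Br)c(Br)c(Br)c(Br)c21` gives 98%, the higher of the two numbers measured and thus the weaker effect, while compound 1 `N#CCCn1cnc2c(Br)c(Br)c(Br)c(Br)c21` gives 80%. Compound 3 `N#CCCCn1cnc2c(Br)c(Br)c(Br)c(Br)c21` differs from compound 2 in one place: cyano in place of cyanomethyl on a saturated chain carbon, three bonds along the chain from an aromatic nitrogen. Within the data shown here, the only measured step, a number 18 percentage points higher from compound 1 to compound 2 (beyond the scatter), involved a change of the same kind in the opposite direction, lengthening the chain. Shortening it is therefore expected to lower the number somewhat, by an estimated a number 9 percentage points lower from compound 2 to compound 3 (within the scatter). Compound 3 is estimated at 89%, with a range from 78% to 100%.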

Compound 3, a percentage reported as activity, at one concentration (the size of the read-out at that concentration, not a potency): 85%
Compound 3: the middle estimate sits 4 percentage points above what was measured, within the range that was stated.
By their numbers in this assay, from the lowest: compounds 1 and 3 (each within the scatter of the next); then compound 2.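

In this assay the change from 4-cyanobutyl to 3-cyanopropyl gives a number 13 percentage points lower from compound 2 to compound 3 (beyond the scatter) while the change from 2-cyanoethyl to 3-cyanopropyl gives a number 5 percentage points higher from compound 1 to compound 3 (within the scatter) by comparison. So the number does not follow chain length evenly: among these three chains, only 4-cyanobutyl stands apart from the other two. Nothing available explains this difference.

Still open, going by these compounds, is whether a chain longer than 4-cyanobutyl would raise the number further. On these data alone, it is also open how an amine or a carboxylic acid at the chain end, in place of the nitrile, would compare.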